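Adding a Hydroxyethyl Arm to the Chain of Compound 1

The source may hold more compounds than are shown below. What is called first, only, known or untested is meant among the compounds shown, and "the series" means these compounds.

Three compounds share a common core and were tested in an in vitro functional assay on cells for agonist activity at Bombesin receptor subtype-3 (Homo sapiens), read by luminescence and calcium flux; a lower number here means that less compound is needed, a higher number that more compound is needed for the effect. Compound 1 `CCCCc1cnc(C(C)Cc2ccc(-c3ccccc3C(=O)O)cc2)[nH]1` gives 2760 nM. Compound 2 `O=C(O)c1ccccc1-c1ccc(CCc2ncc(Cc3ccc(Cl)cc3)[nH]2)cc1` gives 2290 nM, a number that cannot be told apart from that of compound 1 within the usual scatter. Compound 3 `O=C(O)c1ccccc1-c1ccc(CCc2ncc(Cc3cccc(F)c3)[nH]2)cc1` gives 159 nM, and its step from compound 1 lies well beyond the scatter. Within the data shown here, the only single-point step among the measured compounds is a 14-fold lower number from compound 2 to compound 3 (1.16 log units; beyond the scatter), which concerns a change on the aromatic group at the far end of the chain.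

Compound 4 `CCCCc1cnc(C(CCCO)Cc2ccc(-c3ccccc3C(=O)O)cc2)[nH]1` differs from compound 1 in a different place: 2-hydroxyethyl in place of hydrogen on a saturated chain carbon, two bonds along the chain from an aromatic carbon. Among the measured compounds shown here, none of the measured steps touches this position, and none exchanges a hydrogen for a group that carries a hydrogen-bond donor and acceptor, so the measured data give no direct guide to its size or direction in this assay. The expectation therefore rests on the value of compound 1 alone, with a wide allowance for a change in either direction. For compound 4 an expected step of a 1.4-fold lower number from compound 1 to compound 4 (0.14 log units; within the scatter) leads to an estimated value of 2000 nM, with a range from 400 nM to 10000 nM.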

Compound 4, half-maximal effective concentration: 1900 nM
Beside the measured number, compound 4's estimate is 1.1-fold (0.02 log units) above it; the range from low to high includes it.
By their numbers in this assay, from the lowest: compound 3; then compounds 4, 2 and 1 (each within the scatter of the next).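

Putting 2-hydroxyethyl in place of hydrogen on a saturated chain carbon, two bonds along the chain from an aromatic carbon, gives in this assay a 1.5-fold lower number from compound 1 to compound 4 (0.16 log units; within the scatter), so compound 1 and compound 4 cannot be told apart. The earlier compounds shown here said nothing about this position, and this single pair now shows that the chain can carry a group of 3 heavy atoms, with a hydrogen-bond donor and acceptor, without a measurable shift in the half-maximal effective concentration. No supporting data are available to explain this outcome, so the result stands only as an observation.

From the compounds shown here alone, what remains open is whether the same tolerance would hold for other groups at this position, such as an amine or a carboxylic acid in place of the hydroxyl, or a longer chain ending in a hydroxyl. Among these compounds, it is also open whether the arm would leave the number just as unmoved on a compound with a 3-fluorophenyl group at the far end of the chain, the feature of the one compound here whose number stands well apart from the others.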